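Lengthening the chain by one carbon in a sigma ligand

The source may hold more compounds than are shown below. What is called first, only, known or untested is meant among the compounds shown, and "the series" means these compounds.

Measured so far:
Compound 1 `O=c1sc2ccccc2n1CCCCCN1CCCCCC1` — 7 nM
Compound 2 `CCC(=O)c1ccc2c(c1)sc(=O)n2CCCCCN1CCCCCC1` — 12.2 nM
Compound 3 `CCCC(=O)c1ccc2c(c1)sc(=O)n2CCCCN1CCCCCC1` — 4.8 nM

All three were tested in an assay on cell membranes for displacement of a labelled ligand from Sigma non-opioid intracellular receptor 1 (Rattus norvegicus); on this read-out lower numbers stand for stronger inhibition and higher numbers for weaker inhibition. Compound 3 holds the lowest of the three numbers; compound 1 sits nearest to it, and the two lie within the usual scatter of each other, whereas compound 2 lies furthest away, beyond the scatter. Among the compounds with values here, the one single-point step among the measured compounds is a 1.7-fold higher number from compound 1 to compound 2 (0.24 log units; within the scatter), which concerns a group on the aromatic ring and does not touch the chain.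

Compound 4 `CCCC(=O)c1ccc2c(c1)sc(=O)n2CCCCCN1CCCCCC1` is not yet measured. It differs from compound 3 in one place: (azepan-1-yl)methyl in place of azepan-1-yl on a saturated chain carbon, four bonds along the chain from an aromatic nitrogen. Within the data shown here, no measured pair isolates this change, so the only guide is that compounds 1 and 2, which both carry the longer chain, give numbers close to compound 3 in this assay. The step from compound 3 to compound 4 is therefore expected to be small, a 1.5-fold higher number from compound 3 to compound 4 (0.16 log units; within the scatter), and not beyond the scatter in either direction. Compound 4 is estimated at 7 nM, with a likely range from 2.5 nM to 20 nM.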

Compound 4, inhibition constant: 16.3 nM
Compound 4: the middle estimate sits 2.3-fold (0.37 log units) below what was measured; low and high end bracket the measured number.
By their numbers in this assay, from the lowest: compounds 3, 1, 2 and 4 (each within the scatter of the next, the first and the last beyond it).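

In this assay, within the data shown here, the change to (azepan-1-yl)methyl from azepan-1-yl on this saturated chain carbon gives a 3.4-fold higher number from compound 3 to compound 4 (0.53 log units; beyond the scatter) and is the first single-point pair to isolate the length of the chain. With propylcarbonyl held on the aromatic ring, the added carbon weakens inhibition by more than the usual scatter, so this part of the chain is not free to change in this pair. The ring substituent also shows something new: propylcarbonyl in place of hydrogen gives a 2.3-fold higher number from compound 1 to compound 4 (0.37 log units; beyond the scatter) and lies beyond the scatter, whereas the methyl that turns propanoyl into propylcarbonyl gives a 1.3-fold higher number from compound 2 to compound 4 (0.13 log units; within the scatter) and stays within it.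

On these data alone, whether the same chain step appears without propylcarbonyl on the aromatic carbon remains open, as does the effect of a still shorter chain or of a piperidine ring in place of azepan-1-yl. No measurement at hand offers an explanation for these steps.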